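Swapping the amide aryl group for a chloropyridine

This account rests on a few compounds, and the source may have more. Where it says the series, first, only, none or still open, it means among the compounds named here.

Three compounds share one core and differ only in the aryl group attached to the amide carbonyl. In a functional assay on HCC1937 cells (Homo sapiens) for antiproliferative activity, read by CCK-8 assay, with a stated time of 72 h (a higher number here means a weaker inhibitor, a lower number a stronger inhibitor), compound 1 `O=C(Nc1cccc(-c2oc3cc(-c4ccc(F)cc4)ccc3c(=O)c2O)c1)c1ccccc1F` gives 10800 nM, compound 2 `Cc1ccccc1C(=O)Nc1cccc(-c2oc3cc(-c4ccc(F)cc4)ccc3c(=O)c2O)c1` gives 9900 nM, and compound 3 `Cc1cccc(C(=O)Nc2cccc(-c3oc4cc(-c5ccc(F)cc5)ccc4c(=O)c3O)c2)c1` gives 8030 nM; all three numbers lie within the usual scatter of one another, so compound 3 stands level with the rest. The steps of a 1.1-fold lower number from compound 1 to compound 2 (0.04 log units; within the scatter), a 1.3-fold lower number from compound 1 to compound 3 (0.13 log units; within the scatter) and a 1.2-fold lower number from compound 2 to compound 3 (0.09 log units; within the scatter) each stay within that scatter. Compound 4 `O=C(Nc1cccc(-c2oc3cc(-c4ccc(F)cc4)ccc3c(=O)c2O)c1)c1ccc(Cl)nc1` brings (6-chloropyridin-3-yl in place of 3-methylphenyl on a carbonyl carbon). Within the data shown here, none of the measured steps tried a ring with a hetero atom, so they show only that small changes at this position left this assay unmoved. The expected step is therefore a 1.0-fold lower number from compound 3 to compound 4 (0.00 log units; within the scatter), nothing beyond the scatter. Compound 4 is estimated at 8000 nM, ranging from 3000 nM to 22000 nM.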

Compound 4, half-maximal inhibitory concentration: 7550 nM
Estimate against measurement, compound 4: 1.1-fold (0.03 log units) above; the measured number falls inside the stated range.
By their numbers in this assay, from the lowest: compounds 4, 3, 2 and 1 (each within the scatter of the next).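

Replacing a carbon-only ring with 6-chloropyridin-3-yl, a ring with a hetero atom, on the carbonyl carbon gives the steps of a 1.1-fold lower number from compound 3 to compound 4 (0.03 log units; within the scatter) and a 1.3-fold lower number from compound 2 to compound 4 (0.12 log units; within the scatter) and a 1.4-fold lower number from compound 1 to compound 4 (0.16 log units; within the scatter) in this assay and all of them stay within the scatter. Among these compounds, this position therefore tolerates a ring nitrogen and a chlorine, with the number left level with those of the earlier compounds. Nothing measured here offers an explanation for this flat result.

On these data alone, an amine or a carboxylic acid on this ring, or a longer chain in its place, remains open. Whether any group at this position can move the number beyond the scatter also remains unanswered.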